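Cytotoxicity of chromone acrylamides: from fluorobenzyl to methoxybenzyl

The compounds below may be only part of what the source reports. "The series", "measured", "known", "first", "only" and "open" are said of these compounds alone.

Compound 1 `COc1ccc2c(=O)c(/C=C/C(=O)Nc3ccccc3)coc2c1`: 523000 nM
Compound 2 `COc1ccc2c(=O)c(/C=C/C(=O)NCc3ccccc3F)coc2c1`: 146000 nM

Of the compounds shown here, two sharing one core have been tested in an ADME assay on HepG2 2.2.15 cells (Homo sapiens) for cytotoxicity, read by MTT assay, with stated times of 48 h and 9 days; a higher number here means that more compound is tolerated, a lower number that less compound is tolerated. Compound 1 gives 523000 nM, while compound 2 gives 146000 nM. Going by the values given here, the step of a 3.6-fold lower number from compound 1 to compound 2 (0.55 log units; beyond the scatter) is the only measured step here, and it leaves compound 2 with the lowest of the two numbers, with compound 1 as its nearest neighbour.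

Compound 3 `COc1ccc(CNC(=O)/C=C/c2coc3cc(OC)ccc3c2=O)cc1` has not yet been measured. It differs from compound 2 in one place: 4-methoxyphenyl in place of 2-fluorophenyl on a saturated chain carbon bound to an amide-type nitrogen. Among the compounds with values here, the single measured step, a 3.6-fold lower number from compound 1 to compound 2 (0.55 log units; beyond the scatter), concerns a different kind of change, the exchange of a phenyl for a 2-fluorobenzyl on the amide-type nitrogen, so it bears only loosely on the present one. Within the data shown here, no measured pair shows what replacing a fluorine on the aromatic ring by a methoxy group does in this assay. The expectation is therefore a step of a 1.2-fold higher number from compound 2 to compound 3 (0.09 log units; within the scatter), that is, no change beyond the scatter. Compound 3 is estimated at 180000 nM, with a range from 70000 nM to 450000 nM.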

Compound 3, half-maximal cytotoxic concentration: 43000 nM
For compound 3 the middle estimate is 4.2-fold (0.62 log units) above the measured one; measured number outside the range, below it.
By their numbers in this assay, from the lowest: compound 3; then compound 2; then compound 1.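

Exchanging 2-fluorophenyl for 4-methoxyphenyl on the saturated chain carbon bound to the amide-type nitrogen is not a neutral swap in this assay: it gives a 3.4-fold lower number from compound 2 to compound 3 (0.53 log units; beyond the scatter), so the group on the aromatic ring matters here even with the chain to the amide left unchanged. Measured against the phenyl of compound 1, the 4-methoxybenzyl group gives a 12-fold lower number from compound 1 to compound 3 (1.09 log units; beyond the scatter), the largest step in this small set, and it leaves compound 3 as the compound tolerated at the lowest concentration of the three. Nothing measured here accounts for this drop, and the reason for it remains unknown.

The step from 2-fluorobenzyl to 4-methoxybenzyl replaces the fluorine with a methoxy group and also changes where the ring carries its group, and the compounds shown cannot separate these two parts of the change. As far as these compounds go, it also remains open how a plain benzyl group with nothing on its ring would compare, and whether a ring carrying an amine or a carboxylic acid would move the number in the same direction.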